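The source may hold more compounds than are shown below. What is called first, only, known or untested is meant among the compounds shown, and "the series" means these compounds.

Three compounds built on the same shared core have been run in a functional assay on U-937 cells (Homo sapiens) for cytotoxicity, read by MTT assay, with a stated time of 24 h; a lower number here means a stronger inhibitor, a higher number a weaker inhibitor. Compound 1 `COc1ccccc1N1CCN(CCCCCOc2c(Br)cc(Br)cc2Oc2ccc(Br)cc2Br)CC1` gives 37.5 ug/mL. Among the measured compounds shown here, compound 3 `Brc1ccc(Oc2cc(Br)cc(Br)c2OCCCCCN2CCN(C/C=C/c3ccccc3)CC2)c(Br)c1` gives 32.7 ug/mL, and the only single-point step measured so far, a 1.1-fold lower number from compound 1 to compound 3 (0.06 log units; within the scatter), is therefore flat. Compound 2 `C=CCOc1c(Br)cc(Br)cc1Oc1ccc(Br)cc1Br` gives 29 ug/mL, the smallest of the three numbers, yet its gap to compound 3 and to compound 1 is within the scatter, so the three cannot be told apart. Compound 4 `CCOC(=O)C(C)Oc1c(Br)cc(Br)cc1Oc1ccc(Br)cc1Br` differs from compound 2 by 1-(ethoxycarbonyl)ethyl in place of allyl on an oxygen on an aromatic ring. For the measured compounds named here, no measured step touches this oxygen, and the one step that exists stayed within the scatter, so nothing points to a shift. Compound 4 is expected to sit close to compound 2, with a 1.0-fold higher number from compound 2 to compound 4 (0.01 log units; within the scatter), an estimate of 30 ug/mL spanning 15 ug/mL to 60 ug/mL.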

Compound 4, half-maximal inhibitory concentration: 39.5 ug/mL
Compound 4: middle estimate off by 1.3-fold (0.12 log units), on the low side, and the stated range covers the measured number.
By their numbers in this assay, from the lowest: compounds 2, 3, 1 and 4 (each within the scatter of the next).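

Among the compounds shown here, replacing allyl with 1-(ethoxycarbonyl)ethyl on the oxygen on an aromatic ring is the first measured change at this position, and it gives a 1.4-fold higher number from compound 2 to compound 4 (0.13 log units; within the scatter) with no real shift. The position therefore accepts a group of seven heavy atoms in place of three, with two hydrogen-bond acceptors where allyl has none, and the number stays within the scatter. No measurement on hand offers a reason for this. Still open, as far as these compounds go, is whether an amine or a carboxylic acid on this oxygen would move the number beyond the scatter.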